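The source may hold more compounds than are shown below. What is called first, only, known or untested is meant among the compounds shown, and "the series" means these compounds.

Measured so far:
compound 1, `CC(=O)c1ccc(NC(=O)CSc2nc3c([nH]2)c(=O)n(C)c(=O)n3C)cc1`, giving 6400 nM
compound 2, `CC(=O)c1ccc(NC(=O)CSc2nc3[nH]c(=O)n(C)c(=O)c3[nH]2)cc1`, giving 6900 nM
compound 3, `Cn1c(=O)c2[nH]c(SC/C(=N/O)c3ccccc3)nc2n(C)c1=O`, giving 6700 nM

All three were run in a functional assay on HT-29 cells (Homo sapiens) for inhibition, read by MTT assay, with a stated time of 48 h; a lower number here means a stronger inhibitor, a higher number a weaker inhibitor. Compound 2 differs from compound 1 by hydrogen in place of methyl on an aromatic nitrogen, and the step in this assay from compound 1 to compound 2 is a 1.1-fold higher number from compound 1 to compound 2 (0.03 log units; within the scatter), so the change leaves the number essentially where it was. Compound 3 carries a different group on the shared sulfur-linked chain, and the difference between the two cores of compound 1 and compound 3 is not broken down here; its value in this assay sits within the scatter of both compound 1 and compound 2.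

Compound 4, `Cn1c(=O)[nH]c2nc(SC/C(=N/O)c3ccccc3)[nH]c2c1=O`, is not yet measured. It differs from compound 3 by hydrogen in place of methyl on an aromatic nitrogen, which is the same change as that from compound 1 to compound 2, at a place described in identical terms. The step from compound 3 to compound 4 is therefore expected to be a 1.0-fold higher number from compound 3 to compound 4 (0.02 log units; within the scatter), resting on the earlier step of a 1.1-fold higher number from compound 1 to compound 2 (0.03 log units; within the scatter), which showed no movement beyond the scatter. Compound 4 is estimated at 7000 nM, expected between 3500 nM and 14000 nM.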

Compound 4, half-maximal inhibitory concentration: 2100 nM
For compound 4 the middle estimate is 3.3-fold (0.52 log units) above the measured one, and the stated range ends above it.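

In this assay, hydrogen in place of methyl on an aromatic nitrogen gives a 3.2-fold lower number from compound 3 to compound 4 (0.50 log units; beyond the scatter), whereas the same change left the number essentially in place on the core of compound 1. The change therefore cannot be carried at a fixed size from one core to the other in this series, and the step seen on one core was no guide to the step on the other: the same change on two cores in this assay, a 1.1-fold higher number (0.03 log units; within the scatter) from compound 1 to compound 2 and a 3.2-fold lower number (0.50 log units; beyond the scatter) from compound 3 to compound 4, 3.4-fold (0.54 log units) apart, beyond the scatter of two such steps

Among these compounds, with only two matched pairs, this does not show which feature of the sulfur-linked chain goes with the different outcome, nor does it give a reason for the difference or indicate how the change would behave on a third core.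

Still open is whether the step on the core of compound 3 is specific to hydrogen, since an ethyl group or a longer chain on that aromatic nitrogen does not appear among these compounds. Also open, from the compounds shown here alone, is how the same change would read with an amine or a carboxylic acid on the sulfur-linked chain.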